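A few compounds are considered here, and "the series" means these few. Any claim that something is new, unique, unknown or untested is made for them only; others in the source may bear on it.

Among the compounds with values here, compound 1 `C/N=C(/NC#N)NCCCn1nc(-c2ccccc2)ccc1=O` gives 40.5% in a functional assay on the whole organism with Rattus norvegicus as the target, at a dose of 100 mg/kg (on this read-out lower numbers stand for less inhibition and higher numbers for more inhibition at the one dose given (going by the name of the read-out)), and stands highest of the two numbers so far; compound 2 `O=c1ccc(-c2ccccc2)nn1CCCNC(=S)Nc1ccccc1` gives 12.1% in this assay, a gap beyond the scatter. Compound 3 `N#CNC(=N)NCCCCCn1nc(-c2ccccc2)ccc1=O` is not yet measured in this assay. It differs from compound 1 by a group of 8 heavy atoms (4 carbon, 4 nitrogen; no ring) in place of a group of 7 heavy atoms (3 carbon, 4 nitrogen; no ring), on a saturated chain carbon, three bonds along the chain from an aromatic nitrogen. Within the data shown here, no measured pair shows this change, so no step size can be read from the data. Compound 3 is expected to stay close to compound 1, which gives 40.5%, and the expected step of a number 4.5 percentage points lower from compound 1 to compound 3 (within the scatter) is none beyond the scatter. The estimate for compound 3 is 36%, with a range from 16% to 56%.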

Compound 3, a percentage reported as inhibition, in the whole organism at one dose (the size of the read-out at that dose, not a potency): 31%
Beside the measured number, compound 3's estimate is 5 percentage points above it; measured number inside the range.
By their numbers in this assay, from the lowest: compound 2; then compounds 3 and 1 (each within the scatter of the next).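

In this assay, the position on a saturated chain carbon, three bonds along the chain from an aromatic nitrogen, now gives its first readable step: the group of 8 heavy atoms in place of the group of 7 heavy atoms gives a number 9.5 percentage points lower from compound 1 to compound 3 (within the scatter). This single change therefore leaves the read-out at the one dose given without a difference beyond the usual scatter.

From the compounds shown here alone, whether an amine or a carboxylic acid at this position would do the same remains open. No measurement at hand bears on what lies behind this result.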